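The source may report more compounds than this note shows. Statements on the series, on what has been measured and on what is new or still open speak of the compounds shown alone.

Measured so far:
Compound 1 `CCCNc1ncnc2c1cnn2-c1ccccc1` — in a functional assay on G-361 cells (Homo sapiens) for cytotoxicity, read by sulforhodamine B assay (a higher number here means that more compound is tolerated, a lower number that less compound is tolerated), compound 1 gives > 100000 nM, a limit of the assay.
Compound 2 `CCCNc1nc(C)nc2c1cnn2-c1ccccc1` — in this assay compound 2 gives > 100000 nM, a limit of the assay.
Compound 3 `Cc1nc(NC(C)C)c2cnn(-c3ccccc3)c2n1` — in this assay compound 3 gives > 100000 nM, a limit of the assay.

Going by the values given here, compound 3 stands where the other two stand: every value sits at the limit of > 100000 nM in this assay, at which 3 of the 3 values shown sit, so no compound has yet given a read number in this assay. The two steps among the measured compounds, a step that the two limits leave unreadable from compound 1 to compound 2 and a step that the two limits leave unreadable from compound 2 to compound 3, each run from one limit to another and show neither size nor direction.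

Compound 4 `CCCCNc1nc(C)nc2c1cnn2-c1ccccc1` differs from compound 3 in that (butyl in place of isopropyl on a nitrogen on an aromatic ring). The step that bears most closely on this change is the swap of the chain on the same nitrogen, from compound 2 to compound 3, and that step is unreadable. What the series does show is that neither the methyl on the aromatic carbon nor the change of chain brought any compound off the limit. The expected step from compound 3 to compound 4 in this assay is therefore a step that the limit leaves unreadable from compound 3 to compound 4, none beyond the scatter, with the result most likely again reported as a limit. Compound 4 is estimated at 150000 nM in this assay, with a range from 60000 nM to 400000 nM.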

Compound 4, concentration lethal to 50% of the cells: > 100000 nM
Compound 4 was reported as a limit; the forecaster's own chance of this, stated with the estimate: 85%; the middle value lies beyond the limit too.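

Neither the step from compound 3 to compound 4 nor the step from compound 2 to compound 4 can be read, as each runs from one limit to another: the limit of > 100000 nM in this assay, at which 4 of the 4 values shown sit.

The compounds shown leave open whether any change to the chain on the nitrogen, or to the shared core, gives a read number in this assay.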